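Moving the methyl group onto the amide nitrogen

A few compounds are considered here, and "the series" means these few. Any claim that something is new, unique, unknown or untested is made for them only; others in the source may bear on it.

Going by the values given here, in an assay for inhibition of 6-phosphofructo-2-kinase/fructose-2,6-bisphosphatase 3 (Homo sapiens), read by ADP-Glo, with a stated time of 2 h (a higher number here means a weaker inhibitor, a lower number a stronger inhibitor), compound 3 `CN1CCC(CNC(=O)c2ccncc2Nc2cc(-c3ccc4ccn(C)c4c3)c3nccnc3c2)C1` gives 74 nM, the lowest of the three numbers so far, though compound 1 `CNC(=O)c1ccncc1Nc1cc(-c2ccc3ccn(C)c3c2)c2nccnc2c1` gives 83 nM, which sits within the scatter of it, while compound 2 `Cn1cc(CNC(=O)c2ccncc2Nc2cc(-c3ccc4ccn(C)c4c3)c3nccnc3c2)cn1` gives 159 nM. The three measured steps, a 1.1-fold lower number from compound 1 to compound 3 (0.05 log units; within the scatter), a 1.9-fold higher number from compound 1 to compound 2 (0.28 log units; within the scatter) and a 2.1-fold lower number from compound 2 to compound 3 (0.33 log units; beyond the scatter), all swap the group on a saturated chain carbon bound to an amide-type nitrogen and stay small.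

Compound 4 `CN1CCC(N(C)C(=O)c2ccncc2Nc2cc(-c3ccc4ccn(C)c4c3)c3nccnc3c2)C1` makes a different kind of change: methyl(1-methylpyrrolidin-3-yl)amino in place of ((1-methylpyrrolidin-3-yl)methyl)amino on a carbonyl carbon. Among the compounds with values here, no measured step touches the amide nitrogen itself, so the expectation rests only on how modest every step has been. Compound 4 is therefore expected to give about 140 nM, somewhere between 50 nM and 450 nM. The expected step is a 1.9-fold higher number from compound 3 to compound 4 (0.28 log units; within the scatter), a small weakening at most.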

Compound 4, half-maximal inhibitory concentration: 176 nM
For compound 4 the middle estimate is 1.3-fold (0.10 log units) below the measured one; the range from low to high includes it.
By their numbers in this assay, from the lowest: compounds 3, 1, 2 and 4 (each within the scatter of the next, the first and the last beyond it).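

Giving up the amide hydrogen is the first change here to reach the amide nitrogen itself, and it produces a 2.4-fold higher number from compound 3 to compound 4 (0.38 log units; beyond the scatter). The same tertiary amide also shows a 2.1-fold higher number from compound 1 to compound 4 (0.33 log units; beyond the scatter), so substitution on this nitrogen registers where changes further out on the chain mostly did not, although the 1-methyl-1H-pyrazol-4-yl compound remains level with it, at a 1.1-fold higher number from compound 2 to compound 4 (0.04 log units; within the scatter). Nothing measured here explains these steps. Still open, going by these compounds, is whether the lost hydrogen or the rearranged chain drives the step, and how a 1-methylpiperidin-4-yl group on the amide nitrogen would read.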